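This account rests on a few compounds, and the source may have more. Where it says the series, first, only, none or still open, it means among the compounds named here.

In a functional assay on OVCAR-3 cells (Homo sapiens) for antiproliferative activity, read by MTT assay, with a stated time of 24 h (a lower number here means a stronger inhibitor, a higher number a weaker inhibitor), compound 1 `O=C(NNc1ccccc1Cl)c1ccc(NS(=O)(=O)c2cnc(O)nc2O)cc1` gives 7230 nM, the lowest of the two actual numbers in this small set. Compound 3 `O=C(NNc1ccccc1F)c1cccc(NS(=O)(=O)c2cnc(O)nc2O)c1` gives 17000 nM, a higher number, and that gap lies beyond the scatter. Compound 2 `Cc1cccc(NNC(=O)c2cccc(NS(=O)(=O)c3cnc(O)nc3O)c2)c1` reads > 20000 nM, which is a limit of the assay and not a number.

Compound 4 `O=C(NNC(=O)c1ccccc1Cl)c1ccc(NS(=O)(=O)c2cnc(O)nc2O)cc1` keeps the core of compound 1 but has (2-chlorophenyl)carbonyl in place of 2-chlorophenyl on an amine nitrogen. Among the measured compounds shown here, only one measured step also changes the group at an amine nitrogen: an at least 1.1-fold lower number from compound 2 to compound 3 (0.07 log units; that floor lies within the scatter). That step is a weak guide, as neither of its compounds carries the added carbonyl and its floor stays within the scatter. For the measured compounds named here, no measured step shows the effect of the carbonyl itself, so no change beyond the scatter is expected in this assay, with only a slight lean towards a higher number. The estimated step is a 1.4-fold higher number from compound 1 to compound 4 (0.14 log units; within the scatter). For compound 4 the expected value is 10000 nM, with an estimated range of 3000 nM to 30000 nM.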

Compound 4, half-maximal inhibitory concentration: 5220 nM
The estimate for compound 4 lay 1.9-fold (0.28 log units) above the measured number; the measured number falls inside the stated range.
By their numbers in this assay, from the lowest: compounds 4 and 1 (each within the scatter of the next); then compound 3. At a limit, above all of these: compound 2.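

In this assay, the change to (2-chlorophenyl)carbonyl on this amine nitrogen gives a 1.4-fold lower number from compound 1 to compound 4 (0.14 log units; within the scatter), so compound 1 and compound 4 cannot be told apart. Among the compounds shown here, this is the first measured change at this position that adds a carbonyl rather than exchanging one substituted phenyl for another, and the added carbonyl and its hydrogen-bond acceptor bring no shift beyond the scatter in this small set. No measured evidence shown here bears on the cause of this result.

The compounds shown leave open whether the chlorophenyl ring matters once the carbonyl is present, for instance if a methyl group or a longer alkyl chain takes its place on the carbonyl. They also leave open whether a urea or a sulfonyl group at this nitrogen would read the same as the carbonyl.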